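Removing one chloro from a compound at the assay limit

The source may hold more compounds than are shown below. What is called first, only, known or untested is meant among the compounds shown, and "the series" means these compounds.

Compound 1 (`CNC(=O)c1cc(Oc2ccc(NC(=O)c3cc(-c4ccc(Cl)cc4)ncn3)cc2F)ccn1`) gives > 100000 nM (a limit)
Compound 2 (`CNC(=O)c1cc(Oc2ccc(NC(=O)c3nccc(-c4cccc(Cl)c4)n3)cc2)ccn1`) gives > 100000 nM (a limit)

In a functional assay on A549 cells (Homo sapiens) for cytotoxicity, read by MTT assay, with a stated time of 72 h (a higher number here means a weaker inhibitor, a lower number a stronger inhibitor), compound 1 gives > 100000 nM, which is a limit of the assay and not a number. Compound 2 gives > 100000 nM, also a limit. For the measured compounds named here, compound 1 therefore stands at the end of the measurable range (the limit of > 100000 nM in this assay, at which 2 of the 2 values shown sit), and no step between measured compounds can be read.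

Compound 3 (`CNC(=O)c1cc(Oc2ccc(NC(=O)c3cc(-c4ccccc4)ncn3)cc2F)ccn1`) has hydrogen in place of chloro on an aromatic carbon, so 4-chlorophenyl becomes phenyl (hydrogen in place of chloro on an aromatic carbon). In this assay no change beyond the scatter is expected, and no direction can be favoured. This expectation rests on compound 1, whose limit is > 100000 nM (a limit). The expected move is a number no higher from compound 1 to compound 3 (the limit leaves the size open), by estimate. For compound 3 the estimated value is 100000 nM, with an expected range from 40000 nM to 200000 nM (both estimated).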

Compound 3, half-maximal inhibitory concentration: 23200 nM
The estimate for compound 3 lay 4.3-fold (0.63 log units) above the measured number; measured number below the stated range.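

In this assay, the change of 4-chlorophenyl to phenyl brings an at least 4.3-fold lower number from compound 1 to compound 3 (0.63 log units; beyond the scatter), so the group on this aromatic carbon, para to a large group, does affect the read-out. The full size of this step cannot be read, because the value of compound 1 is a limit and not a number: the limit of > 100000 nM in this assay, at which 2 of the 3 values shown sit.

Compound 3 is the first compound shown to give a number rather than a limit, at 23200 nM, which gives later changes at this position a measured value for comparison.

The compounds shown leave open how other groups in place of the chloro, such as fluoro, methoxy or an amine, would read in this assay. They also leave open whether removing the chloro from compound 2 would bring its value within the measurable range.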